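This account rests on a few compounds, and the source may have more. Where it says the series, first, only, none or still open, it means among the compounds named here.

Compound 1, `O=C(O)COc1ccc(Cl)cc1C#Cc1ccc(CO)cc1F`, gives in an in vitro ADME assay on microsomes from liver (Rattus norvegicus) for metabolic stability, read by LC-MS, tested at 1 uM (on this read-out higher numbers stand for fast clearance and lower numbers for slow clearance), a value that is a limit of the assay, < 10 mL.min-1.g-1.
Compound 2, `COCCN(C)S(=O)(=O)c1ccc(C)c(C#Cc2cc(Cl)ccc2OCC(=O)O)c1`, gives in this assay 49 mL.min-1.g-1.
Compound 3, `COCCNS(=O)(=O)c1ccc(C)c(C#Cc2cc(Cl)ccc2OCC(=O)O)c1`, gives in this assay a limit of the assay, < 10 mL.min-1.g-1.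

Compound 3 thus stands at the limit of < 10 mL.min-1.g-1 in this assay, at which 2 of the 3 values shown sit, and no number within that limit is known for it. Compound 4, `Cc1ccc(S(=O)(=O)N2CCCCC2C)cc1C#Cc1cc(Cl)ccc1OCC(=O)O`, differs from compound 3 by 2-methylpiperidin-1-yl in place of (2-methoxyethyl)amino on a sulfonyl sulfur. Going by the values given here, one measured step bears on this change: an at least 4.9-fold lower number from compound 2 to compound 3 (0.69 log units; beyond the scatter), which adds a hydrogen to the sulfonamide nitrogen. Compound 4, like compound 2, carries no hydrogen on that nitrogen, so a rise in this assay is expected for compound 4 because of an at least 4.9-fold lower number from compound 2 to compound 3 (0.69 log units; beyond the scatter) read in reverse. Compound 4 is therefore expected to give 40 mL.min-1.g-1, within 12 mL.min-1.g-1 to 130 mL.min-1.g-1. For compound 4 this means an expected step of an at least 4.0-fold higher number from compound 3 to compound 4 (0.60 log units; beyond the scatter).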

Compound 4, intrinsic clearance in microsomes: 418 mL.min-1.g-1
The estimate for compound 4 lay 10-fold (1.02 log units) below the measured number; the whole stated range lies below it.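

Among the sulfonamides without a hydrogen on the nitrogen, the rest of the group on the sulfonyl sulfur still counts in this assay, with an 8.5-fold higher number from compound 2 to compound 4 (0.93 log units; beyond the scatter). Set against (2-methoxyethyl)amino, the 2-methylpiperidin-1-yl group gives an at least 41-fold higher number from compound 3 to compound 4 (1.62 log units; beyond the scatter). That step is only a bound, as compound 3 sits at a limit of the assay: the limit of < 10 mL.min-1.g-1 in this assay, at which 2 of the 4 values shown sit.

On these data alone, what an unsubstituted piperidin-1-yl or a morpholin-4-yl on the sulfonyl sulfur would give stays open, so the effects of the ring and of its methyl cannot be told apart.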